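Trading a nitro-bearing sulfonyl ring for a plain fluorophenyl

This account rests on a few compounds, and the source may have more. Where it says the series, first, only, none or still open, it means among the compounds named here.

Of the compounds shown here, three sharing one core have been tested in a functional assay on DU-145 cells (Homo sapiens) for inhibition, read by trypan blue exclusion, with a stated time of 72 h; on this read-out higher numbers stand for weaker inhibition and lower numbers for stronger inhibition. Compound 1 `Cn1c(=O)c(S(=O)(=O)c2ccc([N+](=O)[O-])cc2F)cc2cnc(Nc3ccc4[nH]ccc4c3)nc21` gives 400 nM, the lowest number of the three, and so the strongest inhibition measured here. Compound 2 `Cn1c(=O)c(S(=O)(=O)c2ccc(F)cc2F)cc2cnc(Nc3ccccn3)nc21` gives 75000 nM, and compound 3 `O=c1c(S(=O)(=O)c2ccc(F)cc2F)cc2cnc(Nc3ccc4[nH]ccc4c3)nc2n1CC1CCCC1` gives 10000 nM; both gaps from compound 1 lie beyond the scatter, but each of those two compounds differs from compound 1 in more than one place, so nothing can be read from them about any single change.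

Compound 4 `Cn1c(=O)c(S(=O)(=O)c2ccc(F)cc2)cc2cnc(Nc3ccc4[nH]ccc4c3)nc21` is the untested one. It differs from compound 1 as follows: 4-fluorophenyl in place of 2-fluoro-4-nitrophenyl on a sulfonyl sulfur. For the measured compounds named here, no pair of measured compounds isolates this change, so the direction rests on the change alone: the group that leaves carries two hydrogen-bond acceptors and the group that enters carries none. In this assay a step of moderate size toward weaker inhibition is expected, a 5.0-fold higher number from compound 1 to compound 4 (0.70 log units; beyond the scatter). Compound 4 is therefore estimated at 2000 nM, within a range from 400 nM to 10000 nM.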

Compound 4, half-maximal inhibitory concentration: 300 nM
Compound 4: middle estimate off by 6.7-fold (0.82 log units), on the high side; the measured number lies below the stated range.
By their numbers in this assay, from the lowest: compounds 4 and 1 (each within the scatter of the next); then compound 3; then compound 2.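

In this assay, for the compounds shown here, the only one-place comparison so far gives a 1.3-fold lower number from compound 1 to compound 4 (0.12 log units; within the scatter), which puts the two compounds level within the scatter. With the rest of the molecule unchanged, this sulfonyl sulfur can therefore carry either 2-fluoro-4-nitrophenyl or 4-fluorophenyl with no measurable change in inhibition of these cells, and the hydrogen-bond acceptors of the group that leaves are not needed to reach this level. Nothing shown here explains why the two groups read alike.

This single step swaps the whole ring substituent pattern at once, so the nitro group and the 2-fluoro substituent cannot be judged separately. Going by these compounds, it also remains open how this position would respond to a plain phenyl ring, a methoxy group or an amine on that ring.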